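A new aryl group on the shared core of compound 3

The compounds below may be only part of what the source reports. "The series", "measured", "known", "first", "only" and "open" are said of these compounds alone.

Compound 3 `CCc1ccc(-c2nc(CNc3ccc(C(=O)NO)cc3)n(-c3ccccc3)n2)cc1` gives 54.6% in an assay on Sf9 cells for inhibition of protein deacetylase HDAC6 (Homo sapiens), read by fluorescence, with a stated time of 40 min, tested at 100 nM; a higher number here means more inhibition at the concentration tested (going by the name of the read-out), a lower number less inhibition. Within the data shown here, of the three compounds measured so far it holds the lowest number: compound 1 `COc1ccc(-n2nc(-c3ccccc3)nc2CNc2ccc(C(=O)NO)cc2)cc1` gives 63.4%, which is within the scatter of compound 3, while compound 2 `COc1ccc(-n2nc(-c3ccc(O)cc3)nc2CNc2ccc(C(=O)NO)cc2)cc1` gives 70.3%, beyond it. Compound 4 `O=C(NO)c1ccc(NCc2nc(-c3ccccc3Cl)nn2-c2ccccc2)cc1` has not yet been measured. Its difference from compound 3 is 2-chlorophenyl in place of 4-ethylphenyl on an aromatic carbon. Among the measured compounds shown here, the only measured step, a number 6.9 percentage points higher from compound 1 to compound 2 (within the scatter), concerns a different group at a different place, so no measured step bears directly on this change. The step expected for this assay is therefore none beyond the scatter, a number 0.4 percentage points higher from compound 3 to compound 4 (within the scatter). Compound 4 is estimated at 55%, with an expected range from 35% to 75%.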

Compound 4, a percentage reported as inhibition, at one concentration (the size of the read-out at that concentration, not a potency): 75%
The estimate for compound 4 lay 20 percentage points below the measured number; measured number inside the range.
By their numbers in this assay, from the lowest: compounds 3, 1, 2 and 4 (each within the scatter of the next, the first and the last beyond it).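

In this assay, 2-chlorophenyl in place of 4-ethylphenyl on this aromatic carbon gives a number 20.4 percentage points higher from compound 3 to compound 4 (beyond the scatter). Among these compounds, this shows that the number responds to which aryl group sits at this position of the shared core, something the only earlier step, at a different place, could not show. Nothing available explains this rise.

Ethyl and chlorine differ in both identity and place on the phenyl ring, so the compounds shown do not separate those two changes. On these data alone, how a phenyl ring carrying an amine or a carboxylic acid would read here also remains open.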